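Benzyl amide of the acetoxy biphenyl series

This account rests on a few compounds, and the source may have more. Where it says the series, first, only, none or still open, it means among the compounds named here.

Compound 3 `CC(=O)Oc1ccc(-c2ccc(F)cc2F)cc1C(=O)NC1CCCCC1` is the lowest of the three measured numbers in a functional assay on the whole organism (Ear) for inhibition, with Mus musculus as the target, at a dose of 40 mg/kg by the oral route; a lower number here means less inhibition, a higher number more inhibition at the dose given (going by the name of the read-out): compound 3 gives 0%. The acid compound 1 `CC(=O)Oc1ccc(-c2ccc(F)cc2F)cc1C(=O)O` gives 13.7%, and the methyl amide compound 2 `CNC(=O)c1cc(-c2ccc(F)cc2F)ccc1OC(C)=O` gives 48.8%. The steps that lead to compound 3 are a number 13.7 percentage points lower from compound 1 to compound 3 (beyond the scatter) and a number 48.8 percentage points lower from compound 2 to compound 3 (beyond the scatter). Compound 4 `CC(=O)Oc1ccc(-c2ccc(F)cc2F)cc1C(=O)NCc1ccccc1` carries benzyl in place of cyclohexyl on an amide-type nitrogen. Among the measured compounds shown here, the one measured change on this nitrogen, from methyl to cyclohexyl, was large and downward; benzyl and cyclohexyl are both large groups on that nitrogen, so only a small step is expected in this assay, if any, and the number for compound 4 is estimated at 8%, within 0% to 30%, an expected step of a number 8 percentage points higher from compound 3 to compound 4 (within the scatter).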

Compound 4, a percentage reported as inhibition, in the whole organism at one dose (the size of the read-out at that dose, not a potency): 34.1%
For compound 4 the middle estimate is 26.1 percentage points below the measured one, and the stated range ends below it.
By their numbers in this assay, from the lowest: compound 3; then compound 1; then compound 4; then compound 2.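

Read in this assay the amide-type nitrogen does not treat its large groups alike: cyclohexyl and benzyl part clearly (a number 34.1 percentage points higher from compound 3 to compound 4 (beyond the scatter)). Benzyl stays short of methyl (a number 14.7 percentage points lower from compound 2 to compound 4 (beyond the scatter)). Unlike cyclohexyl, it still improves on the acid (a number 20.4 percentage points higher from compound 1 to compound 4 (beyond the scatter)).

Nothing available explains why the saturated and aromatic rings differ. Open, as far as these compounds go, is whether phenethyl, a longer chain, or a benzyl carrying an amine or a carboxylic acid on its ring would keep or lose the benzyl result.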